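A few compounds are considered here, and "the series" means these few. Any claim that something is new, unique, unknown or untested is made for them only; others in the source may bear on it.

Working notes on the series. In a functional assay on MGC-803 cells (Homo sapiens) for inhibition, read by sulforhodamine B assay (on this read-out higher numbers stand for weaker inhibition and lower numbers for stronger inhibition), compound 1 `COc1cccc(NC2=CC(=O)c3c(nc4n3[C@H]3OC[C@@H](O)[C@H]3OC4)C2=O)c1` gives 1790 nM, compound 2 `Cc1ccc(NC2=CC(=O)c3c(nc4n3[C@H]3OC[C@@H](O)[C@H]3OC4)C2=O)cc1` gives 1550 nM, and compound 3 `O=C1C(Nc2ccc(I)cc2)=CC(=O)c2c1nc1n2[C@H]2OC[C@@H](O)[C@H]2OC1` gives 2150 nM. Compound 3 returns the highest of the three numbers, but its nearest neighbour is compound 1 with a 1.2-fold higher number from compound 1 to compound 3 (0.08 log units; within the scatter), and its furthest is compound 2 with a 1.4-fold higher number from compound 2 to compound 3 (0.14 log units; within the scatter); the remaining pair shows a 1.2-fold lower number from compound 1 to compound 2 (0.06 log units; within the scatter). Among the compounds with values here, all three measured steps therefore sit inside the usual scatter of this assay, and no compound can be set apart from the others.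

Compound 4 `O=C1C(Nc2cccc(F)c2)=CC(=O)c2c1nc1n2[C@H]2OC[C@@H](O)[C@H]2OC1` differs from compound 3 by 3-fluorophenyl in place of 4-iodophenyl on an amine nitrogen. Within the data shown here, the steps that bear on this change are those that swap the aryl group on the amine nitrogen: a 1.2-fold higher number from compound 1 to compound 3 (0.08 log units; within the scatter) exchanged 3-methoxyphenyl for 4-iodophenyl without leaving the scatter, and a 1.4-fold higher number from compound 2 to compound 3 (0.14 log units; within the scatter) exchanged methyl for iodo on an aromatic carbon with the same outcome. Among the measured compounds shown here, since every aryl variation so far has stayed within the scatter, no step beyond it is expected in this assay for compound 4, so a 1.2-fold lower number from compound 3 to compound 4 (0.08 log units; within the scatter) is the expected step. Compound 4 is estimated at 1800 nM, with a range from 900 nM to 3600 nM.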

Compound 4, half-maximal inhibitory concentration: 1470 nM
Beside the measured number, compound 4's estimate is 1.2-fold (0.09 log units) above it, and the stated range covers the measured number.
By their numbers in this assay, from the lowest: compounds 4, 2, 1 and 3 (each within the scatter of the next).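

In this assay, 3-fluorophenyl in place of 4-iodophenyl on the amine nitrogen gives (a 1.5-fold lower number from compound 3 to compound 4 (0.17 log units; within the scatter)), so a fluoro-bearing aryl group does not set compound 4 apart from compound 3. The same holds for the other two aryl groups, with 3-fluorophenyl in place of 4-methylphenyl (a 1.1-fold lower number from compound 2 to compound 4 (0.02 log units; within the scatter)) and fluoro in place of methoxy (a 1.2-fold lower number from compound 1 to compound 4 (0.09 log units; within the scatter)), so the four aryl groups on this nitrogen give numbers that cannot be told apart. Nothing at hand offers an explanation for this flat response.

As far as these compounds go, all four compounds carry a substituted phenyl on this nitrogen, so it stays open whether a carboxylic acid or an amine on that ring, or a longer alkyl chain in its place, would move the number beyond the scatter. From the compounds shown here alone, the role of the hydroxyl on the shared core also stays open.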